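A few compounds are considered here, and "the series" means these few. Any claim that something is new, unique, unknown or untested is made for them only; others in the source may bear on it.

Two compounds share one core and differ only on the aromatic ring at its far end. Compound 1 `CC1=CC[C@H](C(C)(C)NC(=S)N/N=C/c2ccccc2)CC1` carries no substituent there, and in a functional assay on U-251 cells (Homo sapiens) for inhibition, read by sulforhodamine B assay, with a stated time of 48 h (on this read-out higher numbers stand for weaker inhibition of growth and lower numbers for stronger inhibition of growth), compound 1 gives 26300 nM. Compound 2 `COc1ccc(/C=N/NC(=S)NC(C)(C)[C@H]2CC=C(C)CC2)cc1` carries a methoxy on that ring, and in this assay compound 2 gives 11400 nM. That single change produced a 2.3-fold lower number from compound 1 to compound 2 (0.36 log units; beyond the scatter). Among the measured compounds shown here, compound 2 therefore stands at the lower of the two numbers known so far, with compound 1 the only comparison.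

Compound 3 `CC1=CC[C@H](C(C)(C)NC(=S)N/N=C/c2ccc(N(C)C)cc2)CC1` differs from compound 2 in one place: dimethylamino in place of methoxy on an aromatic carbon. For the measured compounds named here, no measured pair shows this particular exchange. Going by the values given here, the only step that bears on it is the one from compound 1 to compound 2, which showed that a group at this place can shift the number modestly. A change within or just beyond the scatter is therefore expected. Compound 3 is estimated at 8000 nM, with a range from 3000 nM to 25000 nM. This estimate corresponds to an expected 1.4-fold lower number from compound 2 to compound 3 (0.15 log units; within the scatter).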

Compound 3, concentration for 50% growth inhibition: 57700 nM
Compound 3: middle estimate off by 7.2-fold (0.86 log units), on the low side; measured number outside the range, above it.
By their numbers in this assay, from the lowest: compound 2; then compound 1; then compound 3.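

At this place on the aromatic ring, a group can move the number in either direction in this assay: methoxy lowered it, whereas dimethylamino gives a 2.2-fold higher number from compound 1 to compound 3 (0.34 log units; beyond the scatter). The two groups therefore cannot be treated as interchangeable, since exchanging one for the other gives a 5.1-fold higher number from compound 2 to compound 3 (0.70 log units; beyond the scatter), leaving compound 3 the weakest growth inhibitor of the three. Nothing measured here explains why these two groups differ.

The compounds shown leave open whether a hydroxyl or a primary amine at this place would lie nearer to methoxy or to dimethylamino. From the compounds shown here alone, both substituents sit para to a large group, so it also remains open whether methoxy and dimethylamino would separate in the same way elsewhere on the ring.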